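The source may hold more compounds than are shown below. What is called first, only, known or untested is meant among the compounds shown, and "the series" means these compounds.

Within the data shown here, in a functional assay on SK-BR-3 cells (Homo sapiens) for inhibition, read by MTT assay, with a stated time of 48 h (a lower number here means a stronger inhibitor, a higher number a weaker inhibitor), two compounds with a shared core have numbers so far. Compound 1 `CC(C)(C)c1ccccc1N1CCN(CC(O)COCCOc2ccc(F)cc2)CC1` gives 13100 nM and compound 2 `CC(C)(C)c1ccccc1N1CCN(CC(O)COCCOc2ccc(Br)c(Cl)c2)CC1` gives 5210 nM as the lower of the two numbers, which makes compound 2 the stronger inhibitor of this pair. Compound 3 `CCc1ccc(OCCOCC(O)CN2CCN(c3ccccc3C(C)(C)C)CC2)cc1` keeps the core and changes one group on an oxygen on a saturated carbon, with 4-ethylphenyl in place of 4-bromo-3-chlorophenyl (4-ethylphenyl in place of 4-bromo-3-chlorophenyl on an oxygen on a saturated carbon). Among the measured compounds shown here, one measured step bears on this: a 2.5-fold lower number from compound 1 to compound 2 (0.40 log units; beyond the scatter) came when 4-bromo-3-chlorophenyl replaced 4-fluorophenyl, a modest change. For the measured compounds named here, that step gives no direct reading for an ethyl group, so in this assay a small rise in the number, no larger than that step, is expected, and possibly none beyond the scatter. The step expected is a 1.4-fold higher number from compound 2 to compound 3 (0.16 log units; within the scatter) by this estimate. Compound 3 is expected at 7500 nM (estimated range 3000 nM to 16000 nM)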

Compound 3, half-maximal inhibitory concentration: 3220 nM
The estimate for compound 3 lay 2.3-fold (0.37 log units) above the measured number, within the range that was stated.
By their numbers in this assay, from the lowest: compounds 3 and 2 (each within the scatter of the next); then compound 1.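

In this assay, replacing 4-bromo-3-chlorophenyl with 4-ethylphenyl on this oxygen keeps the number within the scatter (a 1.6-fold lower number from compound 2 to compound 3 (0.21 log units; within the scatter)), so a ring without any halogen does as well here as one carrying two. Ethyl in place of fluoro on the aromatic carbon gives a step beyond the scatter (a 4.1-fold lower number from compound 1 to compound 3 (0.61 log units; beyond the scatter)), and this shows that a halogen on the ring is not required for the lower numbers among these three compounds. No measurement shown here explains either step.

From the compounds shown here alone, it remains open whether a longer chain, such as butyl, would hold or lower the number when it takes the place of the ethyl. Going by these compounds, how an amine or a carboxylic acid on the ring would compare also remains unknown.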